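A few compounds are considered here, and "the series" means these few. Any claim that something is new, unique, unknown or untested is made for them only; others in the source may bear on it.

Measured compounds in an ADME assay on K562 cells (Homo sapiens) for cytotoxicity, read by MTT assay, with a stated time of 72 h; a higher number here means that more compound is tolerated, a lower number that less compound is tolerated:
- compound 1, `Cc1c(CN2CCCC2)cc(-c2ccccc2)n1Nc1ccnc2cc(Cl)ccc12`: 2920 nM
- compound 2, `Cc1c(CN2CCCC2)cc(-c2ccc(Cl)cc2)n1Nc1ccnc2cc(Cl)ccc12`: "not determined" (no result reported)
- compound 3, `CCN(CC)Cc1cc(-c2ccc(F)cc2)n(Nc2ccnc3cc(Cl)ccc23)c1C`: 2360 nM

Three compounds share a core and differ at two places: the group on the aromatic ring attached to the core, and the amine carried on the saturated chain carbon bound to an aromatic carbon. In this assay compound 1 gives 2920 nM and compound 3 gives 2360 nM; the two numbers lie within the usual scatter of each other, so neither can be called better tolerated than the other. For compound 2 no number was reported in this assay, so it gives no guidance.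

Compound 4, `Cc1c(CN2CCCC2)cc(-c2ccc(F)cc2)n1Nc1ccnc2cc(Cl)ccc12`, is the next step from compound 3. The change is pyrrolidin-1-yl in place of diethylamino on a saturated chain carbon bound to an aromatic carbon. Both amines have the same count of atoms and the same single acceptor; the only structural difference is that the chain is closed into a five-membered ring. Compound 1 already carries this ring and sits within the scatter of compound 3, so the step from compound 3 to compound 4 is expected to be small and without a clear direction, estimated as a 1.1-fold higher number from compound 3 to compound 4 (0.03 log units; within the scatter). Compound 4 is therefore expected to give about 2500 nM, within a range from 1200 nM to 5500 nM.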

Compound 4, half-maximal cytotoxic concentration: 1660 nM
The estimate for compound 4 lay 1.5-fold (0.18 log units) above the measured number; measured number inside the range.
By their numbers in this assay, from the lowest: compounds 4, 3 and 1 (each within the scatter of the next).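

In this assay compound 1 and compound 3 differ in two places at once, so neither change could be read alone until now. Pyrrolidin-1-yl in place of diethylamino on a saturated chain carbon bound to an aromatic carbon gives a 1.4-fold lower number from compound 3 to compound 4 (0.15 log units; within the scatter) and so does not separate the two compounds, even though the open chain is closed into a five-membered ring. Fluoro in place of hydrogen on an aromatic carbon gives a 1.8-fold lower number from compound 1 to compound 4 (0.25 log units; within the scatter) and likewise does not separate that pair.

No data are available that could explain either reading.

The compounds shown leave open whether a larger ring amine such as morpholin-4-yl or piperidin-1-yl, on the same saturated chain carbon, would move the number beyond the scatter. They also leave open whether a group such as methoxy or trifluoromethyl in place of fluoro would do so.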